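Methyl on the imidazole carbon: a repeated change

The source may report more compounds than this note shows. Statements on the series, on what has been measured and on what is new or still open speak of the compounds shown alone.

Measured so far:
Compound 1, `COC(=O)N(C)C(C)C#CCn1ccnc1`: 6.6 mg/kg
Compound 2, `COC(=O)N(C)C(C)C#CCn1cncc1C`: 97 mg/kg
Compound 3, `Cn1ccn(CC#CCn2ccnc2)c1=O`: 4.5 mg/kg

All three were tested in a functional assay on the whole organism for agonist activity, with Mus musculus as the target; a lower number here means that less compound is needed, a higher number that more compound is needed for the effect. Compound 2 differs from compound 1 by one change, (methyl in place of hydrogen on an aromatic carbon), and that change brought a 15-fold higher number from compound 1 to compound 2 (1.17 log units; beyond the scatter). Compound 3 has a different core; the difference between the core of compound 3 and the core of compound 1 is not broken down here. The values of compound 3 and compound 1 lie within the usual scatter of each other, so nothing is read into their order.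

Compound 4, `Cc1cncn1CC#CCn1ccn(C)c1=O`, has not been measured. Among the measured compounds shown here, it differs from compound 3 by methyl in place of hydrogen on an aromatic carbon, which is the same change as the one from compound 1 to compound 2, at the same place on the ring. Since that change gave a 15-fold higher number from compound 1 to compound 2 (1.17 log units; beyond the scatter), a step of similar direction and size is expected from compound 3 to compound 4, namely a 10-fold higher number from compound 3 to compound 4 (1.00 log units; beyond the scatter), allowing that a new core may soften or sharpen it. Compound 4 is therefore estimated at 45 mg/kg in this assay, probably between 12 mg/kg and 160 mg/kg.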

Compound 4, dose for half-maximal effect: 100 mg/kg
Compound 4: middle estimate off by 2.2-fold (0.35 log units), on the low side; the measured number falls inside the stated range.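

In this assay, methyl in place of hydrogen on an aromatic carbon gave a 22-fold higher number from compound 3 to compound 4 (1.35 log units; beyond the scatter), so on the core of compound 3 the change again means that much more compound is needed for the effect. The step on this core and the earlier step on the core of compound 1 go the same way and cannot be told apart in size, so in this small set the change carries from one core to the other: the same change on two cores in this assay, a 15-fold higher number (1.17 log units; beyond the scatter) from compound 1 to compound 2 and a 22-fold higher number (1.35 log units; beyond the scatter) from compound 3 to compound 4, 1.5-fold (0.18 log units) apart, within the scatter of two such steps This does not show why methyl has so large an effect, and two cores cannot establish that the same would happen on a third.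

Among the compounds shown, this ring carbon carries only hydrogen or methyl, so it remains open whether ethyl, chlorine or an amine there would shift the number as methyl does. Also open, from the compounds shown here alone, is what methyl would do on the other aromatic carbons of this ring.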